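Halogen for methoxy on the pendant aryl ring

The compounds below may be only part of what the source reports. "The series", "measured", "known", "first", "only" and "open" are said of these compounds alone.

Of the compounds shown here, three sharing one core have been measured. In an assay on HEK-293T cells for displacement of a labelled ligand from corticotropin-releasing factor receptor 1 (Homo sapiens), read by scintillation counting, with a stated time of 2 h (on this read-out lower numbers stand for stronger inhibition and higher numbers for weaker inhibition), compound 1 `CCCCN(CC)c1cc(C)nc2c1NC(=O)CN2c1ccc(Br)cc1Cl` gives 2.7 nM, compound 2 `CCCCN(CC)c1cc(C)nc2c1NC(=O)CN2c1ccc(Br)cc1Br` gives 1.3 nM, and compound 3 `CCCCN(CC)c1cc(C)nc2c1NC(=O)CN2c1ccc(OC)cc1C` gives 4 nM. Compound 3 carries the highest of the three numbers, although it sits within the scatter of compound 1; only compound 2 lies beyond it, with a 3.1-fold higher number from compound 2 to compound 3 (0.49 log units; beyond the scatter). Compound 4 `CCCCN(CC)c1cc(C)nc2c1NC(=O)CN2c1ccc(I)cc1C` differs from compound 3 by iodo in place of methoxy on an aromatic carbon. The step that bears on it most is a 2.1-fold lower number from compound 1 to compound 2 (0.32 log units; beyond the scatter), a halogen swap at the same aromatic carbon, and both halogenated compounds give lower numbers than compound 3. A modest lowering is therefore expected in this assay, a 2.5-fold lower number from compound 3 to compound 4 (0.40 log units; beyond the scatter), so compound 4 is estimated at 1.6 nM, between 0.6 nM and 4.5 nM.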

Compound 4, inhibition constant: 3.4 nM
The estimate for compound 4 lay 2.1-fold (0.33 log units) below the measured number; the measured number falls inside the stated range.
By their numbers in this assay, from the lowest: compound 2; then compounds 1, 4 and 3 (each within the scatter of the next).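

In this assay, iodo and methoxy on this aromatic carbon, para to a large group, cannot be told apart with the methyl group kept: a 1.2-fold lower number from compound 3 to compound 4 (0.07 log units; within the scatter). Compound 4 also cannot be told apart from compound 1, a 1.3-fold higher number from compound 1 to compound 4 (0.10 log units; within the scatter), and only compound 2 stands clear of it, a 2.6-fold higher number from compound 2 to compound 4 (0.42 log units; beyond the scatter), so a halogen at this carbon does not by itself separate compound 4 from compound 3. No available evidence explains this result. Still open, going by these compounds, is how bromo would read on the methyl-bearing ring. An amine or a carboxylic acid at this carbon also remains untested in the compounds shown.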